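A Changed Aromatic Arm on the Scaffold of Compound 2

The compounds below may be only part of what the source reports. "The series", "measured", "known", "first", "only" and "open" are said of these compounds alone.

Of the compounds shown here, three have been measured in an in vitro functional assay on HEK285-7 cells for antagonist activity at prostaglandin D2 receptor 2 (Homo sapiens), read by BRET and beta-arrestin recruitment; on this read-out higher numbers stand for larger maximal responses and lower numbers for smaller maximal responses. Compound 2 `O=C(O)Cc1sc(C(c2ccc(F)cc2)c2ccc(F)cc2)nc1-c1ccnc(N2CCCC2)c1` gives 80% in this assay. Compound 3 `O=C(O)Cc1sc(C(c2ccccc2)c2ccccc2)nc1-c1ccc(F)c(F)c1` reaches 80%, level with compound 2 at the digits shown, so the two lie within the scatter of each other and cannot be ordered; together they stand at the top of the three numbers. Compound 1 `Nc1nc(-c2ccc(Cl)cc2)c(CC(=O)O)s1` gives 50%, which lies well below compound 2 and beyond the scatter.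

Compound 4 `N#Cc1ccc(-c2nc(C(c3ccc(F)cc3)c3ccc(F)cc3)sc2CC(=O)O)cc1` has not yet been measured. Relative to compound 2 it carries 4-cyanophenyl in place of 2-(pyrrolidin-1-yl)pyridin-4-yl on an aromatic carbon. Everything else in the molecule stays as it is in compound 2. Within the data shown here, no pair of measured compounds differs in just one place, so no single-step size has been observed directly. Compound 3 shows that a different aromatic group at this place, with a different large group elsewhere, still reaches 80%, which suggests the maximal response tolerates such exchanges.

The step from compound 2 to compound 4 is therefore expected to be small, a number 5 percentage points lower from compound 2 to compound 4 (within the scatter), most likely within the scatter, with a slight downward lean. For compound 4 the estimated value is 75%, expected to fall between 55% and 95%.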

Compound 4, largest response reached (reported as efficacy), in percent of the reference or control that the assay uses: 30%
Compound 4: middle estimate off by 45 percentage points, on the high side; the measured number lies below the stated range.
By their numbers in this assay, from the lowest: compound 4; then compound 1; then compounds 2 and 3 (each within the scatter of the next).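

In this assay, among these compounds, putting 4-cyanophenyl in place of 2-(pyrrolidin-1-yl)pyridin-4-yl, on the aromatic carbon next to the ring nitrogen, gives a number 50 percentage points lower from compound 2 to compound 4 (beyond the scatter), the only step here that changes a single place. Among the compounds shown here, with the rest of compound 2 held fixed, this shows that the maximal response depends strongly on the group at this position, which no earlier pair could show, as none differed in just one place. Nothing at hand bears on why the number falls so far, so the step stands as an observation without an explanation.

The exchange alters the ring and its substituent at once, since a pyridine bearing a pyrrolidine gives way to a carbon-only ring bearing a nitrile, so the compounds shown do not tell which of these parts carries the step. As far as these compounds go, a morpholine in place of the pyrrolidine on the same pyridine, or a carboxamide in place of the nitrile on the same phenyl, would each change only one of these parts, and how the maximal response would follow remains open.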